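The source may report more compounds than this note shows. Statements on the series, on what has been measured and on what is new or still open speak of the compounds shown alone.

Measured so far:
Compound 1 `COC1=C(C)C(=O)/C(=C(O)/C=C/c2ccc(OC)cc2)C(=O)C1(C)C`: 3 ug/mL
Compound 2 `COC1=C(C)C(=O)/C(=C(O)/C=C/c2ccc(C)cc2)C(=O)C1(C)C`: 4.3 ug/mL
Compound 3 `COC1=C(C)C(=O)/C(=C(O)/C=C/c2ccco2)C(=O)C1(C)C`: 10 ug/mL

In a functional assay on A549 cells (Homo sapiens) for cytotoxicity (on this read-out lower numbers stand for an effect already at smaller amounts and higher numbers for an effect only at larger amounts of compound), compound 1 carries the lowest of the three numbers shown, though compound 2 sits within the scatter of it, a 1.4-fold higher number from compound 1 to compound 2 (0.16 log units; within the scatter). Compound 3 stands clearly apart, a 3.3-fold higher number from compound 1 to compound 3 (0.52 log units; beyond the scatter).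

Compound 4 `COC1=C(C)C(=O)/C(=C(O)/C=C/c2nccs2)C(=O)C1(C)C` differs from compound 1 in one place: 1,3-thiazol-2-yl in place of 4-methoxyphenyl on a double-bonded chain carbon bound to a double-bonded chain carbon. The measured step that bears on this is the one in which a five-membered aromatic ring likewise took the place of the 4-methoxyphenyl, a 3.3-fold higher number from compound 1 to compound 3 (0.52 log units; beyond the scatter); the same ring in place of the 4-methylphenyl gave a 2.3-fold higher number from compound 2 to compound 3 (0.37 log units; beyond the scatter). Both steps point the same way and are modest. Within the data shown here, no measured compound carries a five-membered ring with two hetero atoms, so the size of the step for compound 4 rests on these two steps alone. A modest step toward a higher number is therefore expected, a 2.3-fold higher number from compound 1 to compound 4 (0.37 log units; beyond the scatter). Compound 4 is estimated at 7 ug/mL, with a range of 3.5 ug/mL to 15 ug/mL.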

Compound 4, concentration for half-maximal effect: 3.5 ug/mL
For compound 4 the middle estimate is 2.0-fold (0.30 log units) above the measured one; measured number inside the range.
By their numbers in this assay, from the lowest: compounds 1, 4 and 2 (each within the scatter of the next); then compound 3.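

In this assay, a five-membered aromatic ring at this place, on a double-bonded chain carbon bound to a double-bonded chain carbon, does not by itself go with a higher number: 1,3-thiazol-2-yl in place of 4-methoxyphenyl gives (a 1.2-fold higher number from compound 1 to compound 4 (0.07 log units; within the scatter)), and in place of 4-methylphenyl it gives (a 1.2-fold lower number from compound 2 to compound 4 (0.09 log units; within the scatter)). The two five-membered rings separate instead, with 1,3-thiazol-2-yl in place of furan-2-yl giving (a 2.9-fold lower number from compound 3 to compound 4 (0.46 log units; beyond the scatter)), so the step seen with furan-2-yl does not extend to both such rings. No evidence at hand explains this difference between the two rings.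

Open, from the compounds shown here alone, is whether a saturated ring such as piperidine, or a chain ending in an amine or a carboxylic acid, at this place stays level with compound 1, compound 2 and compound 4. Also open, going by these compounds, is whether a pyridine ring behaves like 1,3-thiazol-2-yl or like furan-2-yl.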